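From 3-methoxyphenyl to 4-fluorophenyl on the shared core

A few compounds are considered here, and "the series" means these few. Any claim that something is new, unique, unknown or untested is made for them only; others in the source may bear on it.

Among the compounds with values here, in a functional assay on MV4-11 cells (Homo sapiens) for antiproliferative activity, read by CCK-8 assay, with a stated time of 72 h (a lower number here means a stronger inhibitor, a higher number a weaker inhibitor), compound 1 (`COc1cccc(-c2cn(C)c(=O)c3[nH]c(C(=O)NCc4ccc(C(=O)Nc5ccccc5N)cc4)cc23)c1`) gives 250 nM and stands level with the only other measured compound. That compound, compound 2 (`Cn1cc(-c2cc(C(C)(C)O)ccc2Oc2ccc(F)cc2F)c2cc(C(=O)NCCCCCCC(=O)NO)[nH]c2c1=O`), also gives 250 nM so the two lie within the scatter of each other. Within the data shown here, the series offers no measured single-change step, so nothing yet shows how far a swap of this kind moves the read-out.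

Compound 3 (`Cn1cc(-c2ccc(F)cc2)c2cc(C(=O)NCc3ccc(C(=O)Nc4ccccc4N)cc3)[nH]c2c1=O`) carries one change from compound 1: 4-fluorophenyl in place of 3-methoxyphenyl on an aromatic carbon of the shared core. The rest of the structure stays as it is. Among the measured compounds shown here, the data hold no example of either group being exchanged on this core, so no direction can be argued. The anchor is compound 1 at 250 nM and nothing firmer. No shift beyond the scatter is expected in this assay and the estimated move is a 1.2-fold higher number from compound 1 to compound 3 (0.08 log units; within the scatter) with wide uncertainty on either side. Compound 3 is expected at 300 nM with an estimated range from 100 nM to 800 nM in the coming measurement.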

Compound 3, half-maximal inhibitory concentration: 220 nM
Estimate against measurement, compound 3: 1.4-fold (0.13 log units) above; low and high end bracket the measured number.
By their numbers in this assay, from the lowest: compounds 3, 1 and 2 (each within the scatter of the next).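

In this assay, the series now has its first measured single-change step at this position: 4-fluorophenyl in place of 3-methoxyphenyl on an aromatic carbon gives a 1.1-fold lower number from compound 1 to compound 3 (0.06 log units; within the scatter). The exchange goes from a group of 8 heavy atoms with 1 hydrogen-bond acceptor to one of 7 heavy atoms with 0 hydrogen-bond acceptors, and the read-out stays within the scatter, a finding that holds for this one pair on the shared core and no further. Nothing measured on these compounds bears on why the step is this small.

On these data alone, it remains open whether the read-out stays this flat with an amine or a carboxylic acid on the phenyl ring, or with a longer alkyl chain in place of the phenyl ring at this aromatic carbon. Compound 2 differs from compound 1 and compound 3 in more than one place, so the compounds shown cannot tell whether the same exchange would give a similar step on the scaffold carrying its hydroxamic acid chain.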